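Aryl variation on the shared core: phenyl for pyridin-3-yl

This account rests on a few compounds, and the source may have more. Where it says the series, first, only, none or still open, it means among the compounds named here.

Three compounds share the core seen in compound 1 `COc1ccc(S(=O)(=O)N2CCc3cccc(-c4ccc([N+](=O)[O-])cc4)c32)cc1` and differ only in the aryl group attached on an aromatic carbon. In a functional assay on HT-29 cells (Homo sapiens) for inhibition, with a stated time of 72 h (a lower number here means a stronger inhibitor, a higher number a weaker inhibitor), compound 1 gives 51.8 nM. Compound 2 `COc1ccc(S(=O)(=O)N2CCc3cccc(-c4cccnc4)c32)cc1` gives 76.3 nM in this assay, and compound 3 `COc1ccc(S(=O)(=O)N2CCc3cccc(-c4cccs4)c32)cc1` gives 200 nM. Compound 2 therefore stands second highest of the three numbers: its nearest neighbour is compound 1, with a 1.5-fold higher number from compound 1 to compound 2 (0.17 log units; within the scatter), and its furthest is compound 3, with a 2.6-fold higher number from compound 2 to compound 3 (0.42 log units; beyond the scatter). The remaining measured step is a 3.9-fold higher number from compound 1 to compound 3 (0.59 log units; beyond the scatter).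

Compound 4 `COc1ccc(S(=O)(=O)N2CCc3cccc(-c4ccccc4)c32)cc1` is not yet measured. It differs from compound 2 in one place: phenyl in place of pyridin-3-yl on an aromatic carbon. All three measured steps are swaps of one aryl group for another at the same position, and none of them is larger than modest; the swap most like this one, between two six-membered rings, is the step from compound 1 to compound 2, which lies within the scatter. For compound 4 in this assay a change of about a 1.1-fold higher number from compound 2 to compound 4 (0.05 log units; within the scatter) is therefore expected, most likely within the scatter and in no firm direction. The number for compound 4 is estimated at 85 nM, with a range from 35 nM to 200 nM.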

Compound 4, half-maximal inhibitory concentration: 96.5 nM
For compound 4 the middle estimate is 1.1-fold (0.06 log units) below the measured one; low and high end bracket the measured number.
By their numbers in this assay, from the lowest: compounds 1, 2 and 4 (each within the scatter of the next); then compound 3.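

In this assay, the ring nitrogen of pyridin-3-yl can be exchanged for carbon without a readable effect (a 1.3-fold higher number from compound 2 to compound 4 (0.10 log units; within the scatter)), and the same holds for removing the nitro group from 4-nitrophenyl (a 1.9-fold higher number from compound 1 to compound 4 (0.27 log units; within the scatter)). Compound 1, compound 2 and compound 4, all carrying a six-membered aromatic ring at this position, therefore cannot be told apart, even though the step to compound 4 takes away the hydrogen-bond acceptor counted for pyridin-3-yl. Compound 3, the only one with thiophen-2-yl, stands apart from the unsubstituted phenyl as well (a 2.1-fold lower number from compound 3 to compound 4 (0.32 log units; beyond the scatter)), a modest step resting on this single five-membered example, and nothing available explains the separation.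

Going by these compounds, it remains open whether the smaller ring or its sulfur atom sets compound 3 apart, a question that a furan-2-yl or thiophen-3-yl group at this position could address. Also open, on these data alone, is how far the flat response among six-membered rings extends, for instance to an amine or a carboxylic acid on the phenyl ring, or to a saturated ring such as morpholine in place of the aryl group.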